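Trimming a methoxy from the aryl ring of compound 1

A few compounds are considered here, and "the series" means these few. Any claim that something is new, unique, unknown or untested is made for them only; others in the source may bear on it.

The measured compounds, all in a functional assay on SNB-19 cells (Homo sapiens) for inhibition, read by sulforhodamine B assay, with a stated time of 48 h; a lower number here means that less compound is tolerated, a higher number that more compound is tolerated:
compound 1 `COc1cc(-c2cc(/C=C/C(=O)c3ccc(N)cc3)[nH]n2)cc(OC)c1OC`, 34000 nM
compound 2 `COc1ccc(-c2cc(/C=C/C(=O)c3ccc(OC)c(OC)c3)[nH]n2)cc1`, 19600 nM
compound 3 `COc1cc(-c2cc(/C=C/C(=O)c3ccc(Cl)c(Cl)c3)[nH]n2)cc(OC)c1OC`, for which the value is a limit of the assay, > 100000 nM

Compound 1 gives the highest of the two plain numbers in this assay, but its nearest neighbour, compound 2, sits within the scatter of it, so no order between the two can be claimed. Within the data shown here, the one step computed among the measured compounds runs from compound 1 to compound 3, an at least 2.9-fold higher number from compound 1 to compound 3 (0.46 log units; beyond the scatter), where 3,4-dichlorophenyl replaces 4-aminophenyl on the carbonyl carbon; its size is only known as a bound, because of the limit of > 100000 nM in this assay, at which 1 of the 3 values shown sits.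

Compound 4 `COc1ccc(-c2cc(/C=C/C(=O)c3ccc(N)cc3)[nH]n2)cc1OC` differs from compound 1 at the other end of the shared core: hydrogen in place of methoxy on an aromatic carbon. Among the measured compounds shown here, none of the measured steps touches this ring, so the change stands without a direct precedent, and the 4-aminophenyl on the carbonyl carbon is kept. With nothing to point either way, the account expects no step beyond the scatter in this assay, estimating a 1.1-fold lower number from compound 1 to compound 4 (0.05 log units; within the scatter). Compound 4 is therefore expected to give about 30000 nM, in the range 10000 nM to 90000 nM.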

Compound 4, concentration lethal to 50% of the cells: 46100 nM
The estimate for compound 4 lay 1.5-fold (0.19 log units) below the measured number, within the range that was stated.
By their numbers in this assay, from the lowest: compounds 2, 1 and 4 (each within the scatter of the next, the first and the last beyond it). At a limit, above all of these: compound 3.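

The step at this position in this assay reads a 1.4-fold higher number from compound 1 to compound 4 (0.13 log units; within the scatter), with hydrogen in place of methoxy on an aromatic carbon. Among these compounds, this is the first reading for this ring, and it shows that this methoxy, ortho to a methoxy group, can leave without a step beyond the scatter, at least while the 4-aminophenyl on the carbonyl carbon is kept. Nothing on hand bears on why the number in this pair stays within the scatter.

From the compounds shown here alone, whether a hydroxyl or an ethoxy in this place would also stay within the scatter remains open, as does whether the same trim holds with 3,4-dichlorophenyl on the carbonyl carbon. For compound 3, which carries that group, the value of > 100000 nM is a limit of the assay, not a number to start from.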